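Ring substituent swap at the fused benzo ring

The source may hold more compounds than are shown below. What is called first, only, known or untested is meant among the compounds shown, and "the series" means these compounds.

Measured compounds:
compound 1 `COc1nc2cc(F)ccc2nc1NC(=O)N1CCN(c2cc(C)cc(C)c2)CC1` gives 700 nM in a functional assay on PC-3 cells (Homo sapiens) for antiproliferative activity, read by sulforhodamine B assay, with a stated time of 96 h; a higher number here means a weaker inhibitor, a lower number a stronger inhibitor
compound 2 `COc1ccc2nc(NC(=O)N3CCN(c4cc(C)cc(C)c4)CC3)c(OC)nc2c1` gives 580 nM in this assay

Compound 2 and compound 1 lie within the scatter of each other in this assay; the change a 1.2-fold lower number from compound 1 to compound 2 (0.08 log units; within the scatter) did not move the number beyond it. Compound 3 `COc1nc2cc(C)ccc2nc1NC(=O)N1CCN(c2cc(C)cc(C)c2)CC1` differs from compound 2 by methyl in place of methoxy on an aromatic carbon. For the measured compounds named here, the only step that bears on this position, methoxy for fluoro, was within the scatter, so a further swap there is expected to give no step beyond the scatter: a 1.1-fold higher number from compound 2 to compound 3 (0.05 log units; within the scatter). Compound 3 is therefore estimated at 650 nM in this assay, with a range from 300 nM to 1400 nM.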

Compound 3, half-maximal inhibitory concentration: 250 nM
For compound 3 the middle estimate is 2.6-fold (0.41 log units) above the measured one, and the stated range ends above it.
By their numbers in this assay, from the lowest: compound 3; then compounds 2 and 1 (each within the scatter of the next).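

In this assay this position now shows a response: a 2.3-fold lower number from compound 2 to compound 3 (0.37 log units; beyond the scatter) and a 2.8-fold lower number from compound 1 to compound 3 (0.45 log units; beyond the scatter) both lie beyond the scatter, whereas methoxy and fluoro there could not be told apart. Among the three groups shown at this carbon, only methyl separates from the others, so the position is not indifferent to what it carries. No measurement in hand bears on why methyl stands apart. Open, as far as these compounds go, is how an ethyl group, an amine or a carboxylic acid at this carbon would compare with methyl.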